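The source may hold more compounds than are shown below. What is called first, only, known or untested is meant among the compounds shown, and "the series" means these compounds.

Three compounds of the series carry a value in a functional assay on the whole organism for activation, with Mus musculus as the target; on this read-out lower numbers stand for an effect already at smaller amounts and higher numbers for an effect only at larger amounts of compound. Compound 1 `CCSc1nc(N)c2nc(O)n(Cc3ccccc3)c2n1` gives 0.1 mg/kg in this assay, and compound 2 `CCCSc1nc(N)c2nc(O)n(Cc3ccccc3)c2n1` gives 0.1 mg/kg. Compound 3 `CCCOc1nc(N)c2nc(O)n(Cc3ccccc3)c2n1` gives 0.3 mg/kg, the highest of the three numbers; the steps of a 3.0-fold higher number from compound 1 to compound 3 (0.48 log units; beyond the scatter) and a 3.0-fold higher number from compound 2 to compound 3 (0.48 log units; beyond the scatter) set it apart, while no change at the digits printed from compound 1 to compound 2 (within the scatter) shows that methyl in place of hydrogen on a saturated chain carbon, two bonds along the chain from a sulfur, left the number where it was.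

Compound 4 `CSc1nc(N)c2nc(O)n(Cc3ccccc3)c2n1` is not yet measured. It differs from compound 3 by methylsulfanyl in place of propoxy on an aromatic carbon. Going by the values given here, the steps that bear on this change are those in which propoxy replaced ethylsulfanyl or propylsulfanyl on the aromatic carbon: a 3.0-fold higher number from compound 1 to compound 3 (0.48 log units; beyond the scatter) and a 3.0-fold higher number from compound 2 to compound 3 (0.48 log units; beyond the scatter), both modest, both beyond the scatter, both toward a higher number for propoxy. Going back to a sulfanyl chain, now methylsulfanyl, is therefore expected to undo that step; since compound 1 and compound 2 did not differ, the shorter chain is not expected to matter much. The step of a 3.0-fold lower number from compound 3 to compound 4 (0.48 log units; beyond the scatter) is expected. For compound 4 the estimate in this assay is 0.1 mg/kg, within 0.03 mg/kg to 0.3 mg/kg.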

Compound 4, minimum effective dose: 0.1 mg/kg
Beside the measured number, compound 4's estimate shows no gap at the digits printed; measured number inside the range.
By their numbers in this assay, from the lowest: compounds 1, 2 and 4 (each within the scatter of the next); then compound 3.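

In this assay methylsulfanyl in place of propoxy gives a 3.0-fold lower number from compound 3 to compound 4 (0.48 log units; beyond the scatter) and so the gap to propoxy now also holds for the shortest of the three sulfanyl chains. Shortening the chain on sulfur gives no change at the digits printed from compound 1 to compound 4 (within the scatter) and no change at the digits printed from compound 2 to compound 4 (within the scatter) and so methylsulfanyl, ethylsulfanyl and propylsulfanyl on this aromatic carbon read alike within the scatter in compound 1, compound 2 and compound 4. No measurement at hand explains the gap between the sulfanyl chains and propoxy.

Propoxy is the only oxygen-linked chain here, so it remains open whether methoxy or ethoxy would read like propoxy or like the sulfanyl chains. Also open, from the compounds shown here alone, is how a longer chain such as pentylsulfanyl, or an amine on this carbon, would read.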